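Swapping the Cyclopentylcarbonyl Group for a Sulfur-Bearing Chain

This account rests on a few compounds, and the source may have more. Where it says the series, first, only, none or still open, it means among the compounds named here.

Compound 3 `COc1ccc(N)c(C(=O)CCNC(=O)C2CCCC2)c1` carries a cyclopentylcarbonyl group on the amine nitrogen, and in an assay for inhibition of Nitric oxide synthase, inducible (Homo sapiens), read by scintillation counting, with a stated time of 30 min, tested at 1 mM (on this read-out lower numbers stand for less inhibition and higher numbers for more inhibition at the one concentration tested (going by the name of the read-out)), compound 3 gives 0.61%. This is the second highest of three numbers: compound 2 `COc1ccc(N)c(C(=O)CCNC(=O)C2CCC2)c1` gives 0.01%, within the scatter (a number 0.6 percentage points higher from compound 2 to compound 3 (within the scatter)), while compound 1 `COc1ccc(N)c(C(=O)CCNC(C)=O)c1` gives 30.7%, well above both (a number 30.1 percentage points lower from compound 1 to compound 3 (beyond the scatter), a number 30.7 percentage points lower from compound 1 to compound 2 (beyond the scatter)). Compound 4 `CNC(=S)NCCC(=O)c1cc(OC)ccc1N` differs from compound 3 by a group of 4 heavy atoms (2 carbon, 1 nitrogen, 1 sulfur; no ring) in place of a group of 7 heavy atoms (6 carbon, 1 oxygen; one five-membered non-aromatic ring of carbon only), on an amine nitrogen. For the measured compounds named here, no measured step covers this change; the two informative steps only exchanged a methyl for a ring on the carbonyl carbon. Since the smallest group gave the highest number, a ring-free entering group is expected to raise the read-out moderately, with wide uncertainty. Compound 4 is estimated at 12%, ranging from 0% to 45%. The expected step is a number 11.4 percentage points higher from compound 3 to compound 4 (beyond the scatter).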

Compound 4, a percentage reported as inhibition, at one concentration (the size of the read-out at that concentration, not a potency): 78.2%
Estimate against measurement, compound 4: 66.2 percentage points below; measured number above the stated range.
By their numbers in this assay, from the lowest: compounds 2 and 3 (each within the scatter of the next); then compound 1; then compound 4.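

On an amine nitrogen, the ring-free sulfur-bearing group raises the read-out in this assay far above both ring-bearing carbonyl groups, a number 77.6 percentage points higher from compound 3 to compound 4 (beyond the scatter) and a number 78.2 percentage points higher from compound 2 to compound 4 (beyond the scatter), and it also exceeds the group without a ring in compound 1, a number 47.5 percentage points higher from compound 1 to compound 4 (beyond the scatter). The earlier pattern, in which the smallest group gave the highest number, therefore fails for compound 4, whose entering group has more heavy atoms than that of compound 1. Nothing available bears on the reason for this rise.

From the compounds shown here alone, it remains open whether a urea, with oxygen in place of the sulfur, would keep this number. Going by these compounds, whether an ethyl in place of the methyl on the entering group would do so is also open.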